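The compounds below may be only part of what the source reports. "The series", "measured", "known", "first", "only" and "open" are said of these compounds alone.

In a functional assay on CHO-K1 cells for antagonist activity at melanin-concentrating hormone receptor 1 (Homo sapiens), read by inositol phosphate accumulation (on this read-out lower numbers stand for stronger inhibition and higher numbers for weaker inhibition), two compounds of this series have been measured. Compound 1 `Cc1nc(N2CCC(O)(C3CC3)CC2)nc2ccc(NC(=O)COc3ccc(OC(F)(F)F)cc3)cc12` gives 33 nM in this assay, while compound 2 `Cc1nc(N2CCC(O)CC2)nc2ccc(NC(=O)COc3ccc(Cl)cc3)cc12` gives 163 nM in this assay. Compound 2 therefore stands with the higher of the two numbers, and its gap to compound 1 lies beyond the usual scatter of repeated measurements.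

Compound 3 `Cc1nc(N2CCN(CC(C)(C)C)CC2)nc2ccc(NC(=O)COc3ccc(Cl)cc3)cc12` has not yet been measured in this assay. It differs from compound 2 in a single place: 4-neopentylpiperazin-1-yl in place of 4-hydroxypiperidin-1-yl on an aromatic carbon. Within the data shown here, no pair of measured compounds isolates this change, so the expectation for compound 3 rests on compound 2 alone and on the general spread seen between the two measured compounds. The step of a 2.0-fold lower number from compound 2 to compound 3 (0.31 log units; beyond the scatter) is expected to be modest and toward a lower number, close to the edge of the scatter. Compound 3 is accordingly estimated at 80 nM in this assay, with a likely range from 25 nM to 260 nM.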

Compound 3, half-maximal inhibitory concentration: 246 nM
Estimate against measurement, compound 3: 3.1-fold (0.49 log units) below, and the stated range covers the measured number.
By their numbers in this assay, from the lowest: compound 1; then compounds 2 and 3 (each within the scatter of the next).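

In this assay, placing 4-neopentylpiperazin-1-yl instead of 4-hydroxypiperidin-1-yl on the aromatic carbon between two ring nitrogen atoms gives a 1.5-fold higher number from compound 2 to compound 3 (0.18 log units; within the scatter), so this change leaves the read-out unresolved from the scatter. The position therefore accommodates a group of 11 heavy atoms with 0 hydrogen-bond donors as well as one of 7 heavy atoms with 1 hydrogen-bond donor, at least with the chloro-bearing side chain held constant. Nothing available here accounts for this outcome.

The compounds shown do not tell how a smaller substituent on the piperazine, such as methyl, or a basic amine or carboxylic acid at this position would read. As far as these compounds go, whether 4-neopentylpiperazin-1-yl would behave the same alongside the trifluoromethoxy group of compound 1 also remains open.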